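Para-hydroxyl for meta-methoxy on the benzyl arm

The source may report more compounds than this note shows. Statements on the series, on what has been measured and on what is new or still open speak of the compounds shown alone.

Compound 1 `COc1cccc(Cc2nn(C[C@H]3CCCN3C)c(=O)c3ccccc23)c1` is the weaker of two measured compounds in an assay for binding affinity to Alpha-1A adrenergic receptor (Homo sapiens) (on this read-out lower numbers stand for stronger inhibition and higher numbers for weaker inhibition), where compound 1 gives 1580 nM. Compound 2 `CN1CCC(Cn2nc(Cc3ccc(Cl)cc3)c3ccccc3c2=O)C1` gives 100 nM in this assay, a difference beyond the usual scatter. Compound 3 `CN1CCC[C@@H]1Cn1nc(Cc2ccc(O)cc2)c2ccccc2c1=O` is not yet measured. It differs from compound 1 in one place: 4-hydroxyphenyl in place of 3-methoxyphenyl on a saturated chain carbon bound to an aromatic carbon. No comparable change among the measured compounds exists to set the size of this step. A small step toward lower numbers is expected, a 2.0-fold lower number from compound 1 to compound 3 (0.30 log units; within the scatter), possibly not beyond the scatter. Compound 3 is therefore estimated at 800 nM, within a range from 200 nM to 3000 nM.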

Compound 3, inhibition constant: 251 nM
Compound 3: the middle estimate sits 3.2-fold (0.50 log units) above what was measured; the measured number falls inside the stated range.
By their numbers in this assay, from the lowest: compound 2; then compound 3; then compound 1.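

In this assay, 4-hydroxyphenyl in place of 3-methoxyphenyl on a saturated chain carbon bound to an aromatic carbon gives a 6.3-fold lower number from compound 1 to compound 3 (0.80 log units; beyond the scatter). Among the compounds shown here, this is the first step read at this position, and it shows that the benzyl arm's substituent can shift the number beyond the scatter while the rest of the molecule stays fixed. The compounds shown leave open whether the step follows from the kind of oxygen group or from where it sits on the ring. A 4-methoxyphenyl or 3-hydroxyphenyl group on the same carbon would separate the two. No measurement at hand accounts for the size of this step.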